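A few compounds are considered here, and "the series" means these few. Any claim that something is new, unique, unknown or untested is made for them only; others in the source may bear on it.

Working notes on the series

All three measured compounds share one core carrying a methoxycarbonyl or carboxy group and one or two benzoyl groups. In an assay on cells for displacement of a labelled ligand from Orexin receptor type 2 (Homo sapiens), read by scintillation counting, with stated times of 10 min and 90 min, tested at 10 uM (on this read-out lower numbers stand for less inhibition and higher numbers for more inhibition at the one concentration tested (going by the name of the read-out)), compound 1 `COC(=O)c1ccc2ccc(C(=O)c3ccccc3)c-2cc1` gives 28.9%. Compound 2 `O=C(O)c1ccc2ccc(C(=O)c3ccccc3)c-2cc1` gives 32.9%; the step of a number 4 percentage points higher from compound 1 to compound 2 (within the scatter), hydrogen in place of methyl on an oxygen next to a carbonyl group, did not move the read-out beyond the scatter. Compound 3 `COC(=O)c1ccc2c(C(=O)c3ccccc3)cc(C(=O)c3ccccc3)c-2cc1` gives -14.5%, the lowest of the three numbers; the step of a number 43.4 percentage points lower from compound 1 to compound 3 (beyond the scatter), benzoyl in place of hydrogen on an aromatic carbon, and the two other compounds both stand beyond the scatter above compound 3.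

Compound 4 `O=C(O)c1ccc2c(C(=O)c3ccccc3)cc(C(=O)c3ccccc3)c-2cc1` has not yet been measured. It differs from compound 3 by hydrogen in place of methyl on an oxygen next to a carbonyl group. For the measured compounds named here, the one measured step that bears on this change is a number 4 percentage points higher from compound 1 to compound 2 (within the scatter), which stayed within the scatter; no other pair shows the same change, so nothing further can be drawn on. The expectation for compound 4 is therefore a step of a number 4.5 percentage points higher from compound 3 to compound 4 (within the scatter), with no movement beyond the scatter from the number of compound 3. Compound 4 is estimated at -10%, expected to fall between -30% and 10%.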

Compound 4, a percentage reported as inhibition, at one concentration (the size of the read-out at that concentration, not a potency): 27%
Beside the measured number, compound 4's estimate is 37 percentage points below it; the whole stated range lies below it.
By their numbers in this assay, from the lowest: compound 3; then compounds 4, 1 and 2 (each within the scatter of the next).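

In this assay, the step of a number 41.5 percentage points higher from compound 3 to compound 4 (beyond the scatter), methoxycarbonyl to carboxy, shows that this change does not leave the read-out unmoved on every core: the same change on two cores in this assay, a number 4 percentage points higher (within the scatter) from compound 1 to compound 2 and a number 41.5 percentage points higher (beyond the scatter) from compound 3 to compound 4, 37.5 percentage points apart, beyond the scatter of two such steps. The step of a number 5.9 percentage points lower from compound 2 to compound 4 (within the scatter), benzoyl in place of hydrogen on an aromatic carbon, shows that with carboxy present the added benzoyl does not move the number beyond the scatter: the same change on two cores in this assay, a number 43.4 percentage points lower (beyond the scatter) from compound 1 to compound 3 and a number 5.9 percentage points lower (within the scatter) from compound 2 to compound 4, 37.5 percentage points apart, beyond the scatter of two such steps. Among these four compounds, the low number stands only where methoxycarbonyl and the second benzoyl occur together, and neither group goes with it alone, as compound 1 and compound 4 show.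

The compounds shown leave open whether this dependence on the partner group extends to other replacements for methoxycarbonyl, such as an ethyl ester or a primary amide, or to a smaller group such as acetyl in place of the second benzoyl. They also leave open how these numbers translate into potency, as each compound is described here by a read-out at a single concentration in one assay.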